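The source may report more compounds than this note shows. Statements on the series, on what has been measured and on what is new or still open speak of the compounds shown alone.

Measured so far:
compound 1, `C/C=C\C(=O)Nc1cc(Nc2nc3c(c(-c4cn(C)c5ccc(F)cc45)n2)CSCC3)c(OC)cc1N(C)CCN(C)C`, 5310 nM
compound 2, `CC/C=C\C(=O)Nc1cc(Nc2nc3c(c(-c4cn(C)c5ccc(F)cc45)n2)CSCC3)c(OC)cc1N(C)CCN(C)C`, 1450 nM
compound 3, `CC/C=C\C(=O)Nc1cc(Nc2nc3c(c(-c4cn(C)c5ccccc45)n2)CSCC3)c(OC)cc1N(C)CCN(C)C`, 236 nM

These three compounds were tested in a functional assay on A549 cells (Homo sapiens) for inhibition, read by MTT assay, with a stated time of 72 h (a higher number here means a weaker inhibitor, a lower number a stronger inhibitor), and they share most of their structure, differing only at the end of an unsaturated chain and at one aromatic position. From compound 1 to compound 2 the change is methyl in place of hydrogen on a saturated chain carbon bound to a double-bonded chain carbon, and this gave a 3.7-fold lower number from compound 1 to compound 2 (0.56 log units; beyond the scatter). From compound 2 to compound 3 the change is hydrogen in place of fluoro on an aromatic carbon, which gave a 6.1-fold lower number from compound 2 to compound 3 (0.79 log units; beyond the scatter). Compound 3 therefore stands lowest of the three in this assay, beyond the scatter of the other two.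

Compound 4, `COc1cc(N(C)CCN(C)C)c(NC(=O)/C=C\C(C)C)cc1Nc1nc2c(c(-c3cn(C)c4ccccc34)n1)CSCC2`, has not yet been measured. It differs from compound 3 by methyl in place of hydrogen on a saturated chain carbon bound to a double-bonded chain carbon and a saturated chain carbon. Within the data shown here, this is the same kind of change as the one from compound 1 to compound 2, but not the same change: there the place was a saturated chain carbon bound to a double-bonded chain carbon, whereas here the saturated chain carbon is bound both to a double-bonded chain carbon and to a saturated chain carbon. The difference between the core of compound 1 and the core of compound 3 is not broken down here.

Among the measured compounds shown here, because the earlier step of this kind gave a 3.7-fold lower number from compound 1 to compound 2 (0.56 log units; beyond the scatter), compound 4 is expected to show a step of a 2.0-fold lower number from compound 3 to compound 4 (0.29 log units; within the scatter) in this assay, kept somewhat smaller since the place is not identical and only one such step is known. The estimated value for compound 4 is 120 nM, with a likely range from 40 nM to 400 nM.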

Compound 4, half-maximal inhibitory concentration: 788 nM
The estimate for compound 4 lay 6.6-fold (0.82 log units) below the measured number, outside the stated range (above it).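

In this assay, a further methyl on the chain turned ethyl into isopropyl and went against the earlier step, giving a 3.3-fold higher number from compound 3 to compound 4 (0.52 log units; beyond the scatter). Set beside that earlier step, a methyl in place of a hydrogen on this chain does not carry over from one core to the other in this series, since the two steps run in opposite directions: the same change on two cores in this assay, a 3.7-fold lower number (0.56 log units; beyond the scatter) from compound 1 to compound 2 and a 3.3-fold higher number (0.52 log units; beyond the scatter) from compound 3 to compound 4, 12-fold (1.09 log units) apart, beyond the scatter of two such steps This does not show what drives the reversal, as the two steps differ in two ways at once: compound 1 and compound 2 carry a fluoro where compound 3 and compound 4 carry a hydrogen, and the methyl enters on a saturated chain carbon bound only to a double-bonded chain carbon in the first step, but on one also bound to a saturated chain carbon in the second.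

The compounds shown leave open how the isopropyl group would behave on the fluoro-bearing core of compound 2, a comparison that would help to separate these two differences. They also leave open whether a longer chain such as propyl, or a chain ending in an amine, would fit either trend.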